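A few compounds are considered here, and "the series" means these few. Any claim that something is new, unique, unknown or untested is made for them only; others in the source may bear on it.

Measured in an ADME assay on L6 cells (Rattus norvegicus) for cytotoxicity, read by resazurin assay, with a stated time of 72 h; on this read-out lower numbers stand for stronger inhibition and higher numbers for weaker inhibition:
Compound 1 `CN1CCN(CCC(=O)N2CCC3(N(C)C)CC(c4ccccc4)C2C(c2ccccc2)C3)CC1`: 128000 nM
Compound 2 `CN1CCN(CC(=O)OC2CC3(N4CCCC4)CC(c4ccccc4)C2C(c2ccccc2)C3)CC1`: 24600 nM
Compound 3 `CN1CCN(CC(=O)N2CCC3(N(C)C)CC(c4ccccc4)C2C(c2ccccc2)C3)CC1`: 195000 nM

Compound 3 stands at the high end of these numbers, level within the scatter with compound 1 and clearly above compound 2. Compound 4 `CN1CCN(CC(=O)N2CCC3(N4CCCC4)CC(c4ccccc4)C2C(c2ccccc2)C3)CC1` differs from it by pyrrolidin-1-yl in place of dimethylamino on a saturated ring carbon. Going by the values given here, no measured step covers this exchange. The only one available, a 1.5-fold higher number from compound 1 to compound 3 (0.18 log units; within the scatter), lies at another place, on a saturated chain carbon bound to a carbonyl carbon. Compound 2, at 24600 nM, also carries pyrrolidin-1-yl but differs elsewhere too, so it supports only a modest lean to a lower number in this assay. The expected change is a 1.8-fold lower number from compound 3 to compound 4 (0.25 log units; within the scatter). For compound 4 the estimate is 110000 nM, expected within 45000 nM to 220000 nM.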

Compound 4, half-maximal inhibitory concentration: 69100 nM
Beside the measured number, compound 4's estimate is 1.6-fold (0.20 log units) above it; the measured number falls inside the stated range.
By their numbers in this assay, from the lowest: compound 2; then compounds 4, 1 and 3 (each within the scatter of the next, the first and the last beyond it).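

In this assay, going by these compounds alone, pyrrolidin-1-yl in place of dimethylamino on the saturated ring carbon gives a 2.8-fold lower number from compound 3 to compound 4 (0.45 log units; beyond the scatter) and so moves the number beyond the scatter, whereas the only earlier step, a 1.5-fold higher number from compound 1 to compound 3 (0.18 log units; within the scatter), at the saturated chain carbon, stayed within it. This ring carbon therefore responds to a change of its amine group in this assay. Nothing available explains the shift. Still open, going by these compounds, is how a piperidin-1-yl or morpholin-4-yl group would read at this ring carbon. Also open, on these data alone, is whether the same exchange gives a similar step on the longer chain of compound 1.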